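The compounds below may be only part of what the source reports. "The series", "measured", "known", "first", "only" and "open" are said of these compounds alone.

Three compounds here share one core and differ only in the group attached to a carbonyl carbon. Compound 1 `Cc1ccccc1C(=O)n1c(-c2cn(-c3ccccc3)nc2-c2ccc(F)cc2)nc2ccccc21` gives 189000 nM in an ADME assay on HEK-293T cells (Homo sapiens) for cytotoxicity, read by MTT assay, with a stated time of 24 h; on this read-out higher numbers stand for lower toxicity in this test and lower numbers for higher toxicity in this test. Among the compounds with values here, compound 3 `O=C(c1cccnc1)n1c(-c2cn(-c3ccccc3)nc2-c2ccc(F)cc2)nc2ccccc21` gives 216000 nM in this assay, and the one recorded step between them, a 1.1-fold higher number from compound 1 to compound 3 (0.06 log units; within the scatter), is a change that stays inside the ordinary scatter of repeated measurements. Compound 2 `Cc1ccc(-c2nn(-c3ccccc3)cc2-c2nc3ccccc3n2C(=O)c2ccc(Cl)cc2)cc1` gives 216000 nM in this assay; it stands level with compound 3 at the digits shown, and its gap to compound 1 is also within the scatter, so the three numbers cannot be told apart.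

Compound 4 `Cc1ccc(-c2nn(-c3ccccc3)cc2-c2nc3ccccc3n2C(=O)c2cccc(C)c2)cc1` is the next compound, and it differs from compound 2 in one place: 3-methylphenyl in place of 4-chlorophenyl on a carbonyl carbon. Within the data shown here, the only measured step that bears on this kind of change is the one from compound 1 to compound 3, which swapped the group on the same carbonyl carbon and moved the number by a 1.1-fold higher number from compound 1 to compound 3 (0.06 log units; within the scatter), a shift within the scatter. On that basis compound 4 is expected to stay close to compound 2, with a step of no change at the digits printed from compound 2 to compound 4 (within the scatter) that is not expected to exceed the scatter. The estimate for compound 4 is 216000 nM, with a range from 108000 nM to 432000 nM.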

Compound 4, half-maximal cytotoxic concentration: 195000 nM
Estimate against measurement, compound 4: 1.1-fold (0.04 log units) above; the measured number falls inside the stated range.
By their numbers in this assay, from the lowest: compounds 1, 4, 2 and 3 (each within the scatter of the next).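

The step in this assay reads a 1.1-fold lower number from compound 2 to compound 4 (0.04 log units; within the scatter), so a second exchange on this carbonyl carbon stays inside the scatter, this time between two carbon-only aromatic rings with different substituents, 4-chlorophenyl and 3-methylphenyl. Together with the earlier step, which reads a 1.1-fold higher number from compound 1 to compound 3 (0.06 log units; within the scatter) and brought in a ring containing nitrogen, this shows that two different exchanges of one six-membered aromatic ring for another leave the number unresolved from its starting point, on two slightly different backgrounds. Nothing measured here offers an explanation for this lack of separation.

Every group shown on this carbonyl carbon is a six-membered aromatic ring, so it remains open whether a butyl chain, a cyclohexyl ring or a phenyl ring bearing a carboxylic acid or an amine would give a number beyond the scatter. As far as these compounds go, it also remains open whether 3-methylphenyl and 4-chlorophenyl would stay just as close on the core of compound 1, as the two steps shown sit on different backgrounds.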